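The compounds below may be only part of what the source reports. "The series", "measured", "known", "first", "only" and "open" are said of these compounds alone.

Compound 1, `CC1(C)[C@H]2CC[C@]1(C)N(Cc1cn(-c3cccc(Cl)c3)nn1)C(=O)C2`, in a functional assay on LoVo cells (Homo sapiens) for inhibition, read by MTT assay, with a stated time of 24 h (a higher number here means a weaker inhibitor, a lower number a stronger inhibitor), gives 70 nM.
Compound 2, `CC1(C)[C@H]2CC[C@]1(C)N(Cc1cn(-c3ccc(Cl)cc3)nn1)C(=O)C2`, gives 160 nM.
Compound 3, `CC1(C)[C@H]2CC[C@]1(C)N(Cc1cn(-c3ccccc3O)nn1)C(=O)C2`, gives 540 nM.

Among these three, compound 3 carries the highest number, and both gaps are beyond the scatter: a 7.7-fold higher number from compound 1 to compound 3 (0.89 log units; beyond the scatter), and a 3.4-fold higher number from compound 2 to compound 3 (0.53 log units; beyond the scatter). Compound 4, `COc1ccccc1-n1cc(CN2C(=O)C[C@@H]3CC[C@@]2(C)C3(C)C)nn1`, differs from compound 3 in one place: methyl in place of hydrogen on an oxygen on an aromatic ring. The three measured steps all exchange one substituted phenyl ring for another on the aromatic nitrogen, as in a 2.3-fold higher number from compound 1 to compound 2 (0.36 log units; beyond the scatter), so none of them tests what happens when the hydrogen on that oxygen is replaced by a methyl. The data therefore offer no direct guide to the direction of this step. Among the compounds with values here, with no measured step on that oxygen to rest on, the expected movement is small and not clearly in either direction, so the estimated step is a 1.1-fold higher number from compound 3 to compound 4 (0.05 log units; within the scatter). Compound 4 is expected to give about 600 nM, with a range from 200 nM to 1800 nM.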

Compound 4, half-maximal inhibitory concentration: 70 nM
Beside the measured number, compound 4's estimate is 8.6-fold (0.93 log units) above it; measured number outside the range, below it.
By their numbers in this assay, from the lowest: compounds 1 and 4 (each within the scatter of the next); then compound 2; then compound 3.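

In this assay, hydroxy to methoxy produces a 7.7-fold lower number from compound 3 to compound 4 (0.89 log units; beyond the scatter) and so shows that this single methyl on the oxygen can clearly shift the number, which the earlier swaps of one whole substituted phenyl ring for another could not show. The 2-methoxyphenyl group also compares well with the chlorinated rings, with a 2.3-fold lower number from compound 2 to compound 4 (0.36 log units; beyond the scatter) against 4-chlorophenyl and no change at the digits printed from compound 1 to compound 4 (within the scatter) against 3-chlorophenyl, so two different substituted phenyl rings reach the same value. No measurement available here explains the effect of the methyl.

The compounds shown leave open whether a longer chain on that oxygen, such as ethyl, would keep the lower number. They also leave open how an amine in place of the hydroxy group would compare.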